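Exchanging the Sulfonyl Chain for 1-Carbamoylpentyl

The source may hold more compounds than are shown below. What is called first, only, known or untested is meant among the compounds shown, and "the series" means these compounds.

Measured so far in a physicochemical assay for lipophilicity, read by HPLC, at pH 7.5; a lower number here means a more polar compound, a higher number a more lipophilic compound:
- compound 1 (`CCOc1ccccc1-c1ccc(-c2nc3cnccc3cc2C#N)cc1`): 3.8
- compound 2 (`CCOc1ccccc1-c1ccc(-c2nc3cnccc3c(N[C@H](CC)C(=O)NS(C)(=O)=O)c2C#N)cc1`): 2.2

In this assay compound 2 stands lowest of the two measured, and compound 1 lies above it by more than the scatter. Compound 3 (`CCCCC(Nc1c(C#N)c(-c2ccc(-c3ccccc3OCC)cc2)nc2cnccc12)C(N)=O`) differs from compound 2 by one change, (a group of 8 heavy atoms (6 carbon, 1 nitrogen, 1 oxygen; no ring) in place of a group of 10 heavy atoms (5 carbon, 1 nitrogen, 3 oxygen, 1 sulfur; no ring), on a nitrogen on an aromatic ring), with 1-carbamoylpentyl as the entering group.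

Among the measured compounds shown here, only one measured step bears on this: a number 1.60 log units lower from compound 1 to compound 2 (beyond the scatter), a large one, which brought in the chain now being exchanged. For the measured compounds named here, no measured pair isolates the exchange itself, so the expectation is uncertain. Much of that large step is expected to be reversed, giving an upward move rather than none. The estimated move is a number 1.50 log units higher from compound 2 to compound 3 (beyond the scatter) in this assay. For compound 3 the expected value is 3.7, with an estimated range from 3.1 to 4.3.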

Compound 3, distribution coefficient: 3.6
Compound 3: middle estimate off by 0.10 log units, on the high side; measured number inside the range.
By their numbers in this assay, from the lowest: compound 2; then compounds 3 and 1 (each within the scatter of the next).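

In this assay, exchanging the sulfonyl-bearing chain for 1-carbamoylpentyl on the nitrogen gives a number 1.40 log units higher from compound 2 to compound 3 (beyond the scatter), so the low number of compound 2 does not hold for every chain at this position. Against the hydrogen of compound 1, the chain of compound 3 gives a number 0.20 log units lower from compound 1 to compound 3 (within the scatter), so across these compounds a substituent on this aromatic carbon does not by itself go with a low number in this assay. Nothing at hand accounts for the gap between the two chains.

The exchange alters the chain length and the sulfonyl part together, leaving their separate shares of the step unresolved. A 1-carbamoylpropyl chain would bear on that split, while a carboxylic acid at the chain end remains an open comparison.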